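The compounds below may be only part of what the source reports. "The series", "measured", "known", "first", "only" and "open" are said of these compounds alone.

Working notes on the series, values from a functional assay on A549 cells (Homo sapiens) for cytotoxicity, read by MTT assay, with a stated time of 72 h; a higher number here means a weaker inhibitor, a lower number a stronger inhibitor:

- compound 1 `CN(C)Cc1ccc2nc(NC(=O)N/N=C/c3cn(Cc4ccccc4Cl)c4ccccc34)sc2c1`: 1080 nM
- compound 2 `CN(C)Cc1ccc2nc(NC(=O)N/N=C/c3cn(Cc4ccc(Cl)cc4)c4ccccc34)sc2c1`: 840 nM

Only these two compounds have been measured so far, and compound 2 at 840 nM stands level with compound 1 within the scatter. The step between them is a 1.3-fold lower number from compound 1 to compound 2 (0.11 log units; within the scatter).

The next compound is compound 3 `Cc1ccc(Cn2cc(/C=N/NC(=O)Nc3nc4ccc(CN(C)C)cc4s3)c3ccccc32)cc1`. Its difference from compound 2 is methyl in place of chloro on an aromatic carbon: 4-chlorobenzyl becomes 4-methylbenzyl, with methyl in place of chloro on an aromatic carbon, para to a large group.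

Going by the values given here, no measured step makes this exchange, so the evidence is indirect. Among the compounds with values here, the one step available, a 1.3-fold lower number from compound 1 to compound 2 (0.11 log units; within the scatter), concerns the same benzyl group, but it swaps 2-chlorophenyl for 4-chlorophenyl and keeps the chloro. It stayed within the scatter, which gives no reason to expect a large shift, though a single pair cannot show how the series responds to losing the chloro. No direction can be argued from these data.

The expected change is a 1.1-fold higher number from compound 2 to compound 3 (0.03 log units; within the scatter), which is no step beyond the scatter. For compound 3 the estimated value is 900 nM, with an expected range of 400 nM to 2000 nM.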

Compound 3, half-maximal inhibitory concentration: 1600 nM
Compound 3: middle estimate off by 1.8-fold (0.25 log units), on the low side; the range from low to high includes it.
By their numbers in this assay, from the lowest: compounds 2, 1 and 3 (each within the scatter of the next).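

In this assay, the exchange at this position, on an aromatic carbon para to a large group, now has a direct reading: 4-methylbenzyl in place of 4-chlorobenzyl gives a 1.9-fold higher number from compound 2 to compound 3 (0.28 log units; within the scatter). The exchange that alters both group and place, 4-methylphenyl in place of 2-chlorophenyl, gives a 1.5-fold higher number from compound 1 to compound 3 (0.17 log units; within the scatter), so the chloro can be lost here without any step leaving the scatter, and the three compounds remain unseparated. No accompanying measurement bears on these results.

Still open, from the compounds shown here alone, is whether any substituent on this benzyl ring can move the number beyond the scatter: a methoxy, a trifluoromethyl or a carboxylic acid in the same place would test that, and a plain benzyl group with no substituent would give the reference point. Also open, going by these compounds, is whether a longer chain in place of the single saturated carbon bound to the aromatic nitrogen would do more than these small exchanges on the ring.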